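Swapping methoxy for nitro on a urea-hydrazone series

This account rests on a few compounds, and the source may have more. Where it says the series, first, only, none or still open, it means among the compounds named here.

Measured compounds:
compound 1, `COc1cc2c(Oc3ccc(NC(=O)N/N=C/c4ccc([N+](=O)[O-])cc4)cc3F)ccnc2cc1OCCCN1CCCC1`, 460 nM
compound 2, `COc1ccc(/C=N/NC(=O)Nc2ccc(Oc3ccnc4cc(OCCCN5CCC(C)CC5)c(OC)cc34)c(F)c2)cc1`, 430 nM

Both were tested in a functional assay on A549 cells (Homo sapiens) for cytotoxicity, read by MTT assay, with a stated time of 72 h; on this read-out lower numbers stand for stronger inhibition and higher numbers for weaker inhibition. Compound 2 gives the lowest of the two numbers, but compound 1 sits within the scatter of it, so the two are indistinguishable here. Compound 3, `COc1cc2c(Oc3ccc(NC(=O)N/N=C/c4ccc([N+](=O)[O-])cc4)cc3F)ccnc2cc1OCCCN1CCC(C)CC1`, is not yet measured. It differs from compound 2 in one place: nitro in place of methoxy on an aromatic carbon, on an aromatic carbon of a six-membered aromatic ring of carbon only. Compound 1 already carries this nitro group and reads within the scatter of compound 2, so no step beyond the scatter is expected. Compound 3 is therefore estimated at 450 nM, between 200 nM and 1000 nM, an expected step of a 1.0-fold higher number from compound 2 to compound 3 (0.02 log units; within the scatter).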

Compound 3, half-maximal inhibitory concentration: 380 nM
Estimate against measurement, compound 3: 1.2-fold (0.07 log units) above; measured number inside the range.
By their numbers in this assay, from the lowest: compounds 3, 2 and 1 (each within the scatter of the next).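

With 4-methylpiperidin-1-yl held fixed, the change from 4-methoxyphenyl to 4-nitrophenyl can now be read alone in this assay as a 1.1-fold lower number from compound 2 to compound 3 (0.05 log units; within the scatter), so the two groups cannot be told apart at this place. Holding the nitro group fixed, 4-methylpiperidin-1-yl in place of pyrrolidin-1-yl gives a 1.2-fold lower number from compound 1 to compound 3 (0.08 log units; within the scatter) and is equally indistinguishable. No other measurement here bears on these results. On these data alone, whether an amine or a carboxylic acid at this place would shift the number remains open, as does the effect of a longer chain leading to the saturated ring.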